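Amino to hydroxy swap on the cyclohexyl amide

A few compounds are considered here, and "the series" means these few. Any claim that something is new, unique, unknown or untested is made for them only; others in the source may bear on it.

Working notes on the cyclohexyl amide series. Compound 2 `Cn1cc(-c2cnc3c(-c4csc(C(=O)N[C@@H]5CCCC[C@@H]5N)c4)cnn3c2)cn1` carries the 2-aminocyclohexyl group on the amide nitrogen. In an assay for inhibition of MAP/microtubule affinity-regulating kinase 3 (Homo sapiens), read by HTRF, with a stated time of 2 h (a higher number here means a weaker inhibitor, a lower number a stronger inhibitor), compound 2 sits at the limit of the assay, reported only as <= 0.5 nM. Compound 1 `Cn1cc(-c2cnc3c(-c4csc(C(=O)N[C@@H]5CCCC[C@H]5O)c4)cnn3c2)cn1`, with 2-hydroxycyclohexyl in its place, gives 24 nM in this assay. Within the data shown here, the single measured step, an at least 48-fold lower number from compound 1 to compound 2 (1.68 log units; beyond the scatter), is the only comparison in hand, and its endpoint is the limit noted in the limit of <= 0.5 nM in this assay, at which 1 of the 2 values shown sits. Compound 3 `Cn1cc(-c2cnc3c(-c4csc(C(=O)N[C@@H]5CCCC[C@@H]5O)c4)cnn3c2)cn1` is the next compound to be measured. The change is hydroxy in place of amino on a saturated ring carbon. This runs the measured step backwards, so a large rise in the number is expected, an at least 30-fold higher number from compound 2 to compound 3 (1.47 log units; beyond the scatter), toward the value of the other hydroxy compound. Compound 3 is therefore expected to give 15 nM in this assay, with a range from 3 nM to 70 nM.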

Compound 3, half-maximal inhibitory concentration: 9 nM
Compound 3: middle estimate off by 1.7-fold (0.22 log units), on the high side, within the range that was stated.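

In this assay, the amino-to-hydroxy change with the drawing of this saturated ring carbon kept gives an at least 18-fold higher number from compound 2 to compound 3 (1.25 log units; beyond the scatter), so the large difference between the two groups does not depend on the opposite drawn configuration of compound 1. Compound 2 stands only at a limit of the assay, <= 0.5 nM, so the full size of this step stays unread: the limit of <= 0.5 nM in this assay, at which 1 of the 3 values shown sits. Configuration also counts among the hydroxy compounds, with a 2.7-fold lower number from compound 1 to compound 3 (0.43 log units; beyond the scatter), a modest step beside the large one: the fact that compounds 1 and 3 differ only in the configuration as drawn.

The compounds shown leave open how an amino group responds to the same change of configuration. They also leave open whether methylamino, dimethylamino, methoxy or aminomethyl at this carbon would stand nearer the amino or the hydroxy compounds.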